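One aryl swap, from compound 2 to compound 3

The source may hold more compounds than are shown below. What is called first, only, known or untested is meant among the compounds shown, and "the series" means these compounds.

Measured in a functional assay on THP-1 cells (Homo sapiens); a higher number here means a weaker inhibitor, a lower number a stronger inhibitor:
Compound 1 `CCSC[C@@](O)([C@@H](Nc1cccc2nc(C)ccc12)c1ccc(OC)cc1)C(F)(F)F` gives 6.31 nM
Compound 2 `CCSC[C@@](O)([C@@H](Nc1cccc2nc(C)ccc12)c1cccc(F)c1OC)C(F)(F)F` gives 2 nM

Compound 2 has the lower of the two numbers (it stands at 2 nM) and so is the stronger inhibitor. Compound 3 `CCSC[C@@](O)([C@@H](Nc1cccc2nc(C)ccc12)c1ccc(Cl)c(F)c1O)C(F)(F)F` carries 4-chloro-3-fluoro-2-hydroxyphenyl in place of 3-fluoro-2-methoxyphenyl on a saturated chain carbon bound to a nitrogen on an aromatic ring and a saturated chain carbon. Within the data shown here, the only measured step at that place, a 3.2-fold lower number from compound 1 to compound 2 (0.50 log units; beyond the scatter), was modest, and it involved different groups. The expected step in this assay, a 1.3-fold lower number from compound 2 to compound 3 (0.12 log units; within the scatter), is therefore small, leaning lower if it shows at all. The estimated value for compound 3 is 1.5 nM (range 0.4 nM to 6 nM).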

Compound 3, half-maximal inhibitory concentration: 20 nM
Compound 3: the middle estimate sits 13-fold (1.12 log units) below what was measured, outside the stated range (above it).
By their numbers in this assay, from the lowest: compound 2; then compound 1; then compound 3.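

In this assay the swap brought a 10-fold higher number from compound 2 to compound 3 (1.00 log units; beyond the scatter) and also a 3.2-fold higher number from compound 1 to compound 3 (0.50 log units; beyond the scatter) so this position can lose as well as gain, and 4-chloro-3-fluoro-2-hydroxyphenyl ranks behind both methoxy-bearing aryl groups. The earlier pair had shown only a gain. Nothing available here accounts for the loss.

The change brings in the chlorine and replaces methoxy with hydroxy in one move, so the compounds shown cannot separate the two. Going by these compounds, a 4-chloro-3-fluoro-2-methoxyphenyl group would sit between them, and how it reads remains open.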